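Swapping the dichlorophenyl of compound 3 for a benzodioxinyl

The source may report more compounds than this note shows. Statements on the series, on what has been measured and on what is new or still open speak of the compounds shown alone.

Three sulfonamides built on the same bis(trifluoromethyl)phenyl core have been measured in a functional assay on BXPC-3 cells (Homo sapiens) for inhibition, read by MTT assay, with a stated time of 72 h; on this read-out higher numbers stand for weaker inhibition of growth and lower numbers for stronger inhibition of growth. Compound 1 `O=S(=O)(NCCNCc1cccc2ccccc12)c1cc(C(F)(F)F)cc(C(F)(F)F)c1` gives 23000 nM, compound 2 `O=S(=O)(NCCCCNCc1ccc(Br)cc1)c1cc(C(F)(F)F)cc(C(F)(F)F)c1` gives 1700 nM, and compound 3 `O=S(=O)(NCCCNCc1ccc(Cl)c(Cl)c1)c1cc(C(F)(F)F)cc(C(F)(F)F)c1` gives 1400 nM. Among the measured compounds shown here, compound 3 carries the lowest number of the three, yet its only close neighbour is compound 2, since a 1.2-fold lower number from compound 2 to compound 3 (0.08 log units; within the scatter), while compound 1 sits far higher. Compound 4 `O=S(=O)(NCCCNCC1COc2ccccc2O1)c1cc(C(F)(F)F)cc(C(F)(F)F)c1` differs from compound 3 in one place: 2,3-dihydro-1,4-benzodioxin-2-yl in place of 3,4-dichlorophenyl on a saturated chain carbon bound to an amine nitrogen. For the measured compounds named here, none of the measured steps touches this exchange; the one step recorded, from compound 2 to compound 3, swaps one halogenated benzyl amine for another and stays within the scatter, so it offers no guide to the size or direction of the move to a benzodioxinyl. With only that to go on, the author expects the change to cost some activity, with a 2.5-fold higher number from compound 3 to compound 4 (0.40 log units; beyond the scatter) as the estimated step in this assay. Compound 4 is therefore estimated at 3500 nM, within a range from 1200 nM to 12000 nM.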

Compound 4, concentration for 50% growth inhibition: 1200 nM
The estimate for compound 4 lay 2.9-fold (0.46 log units) above the measured number, within the range that was stated.
By their numbers in this assay, from the lowest: compounds 4, 3 and 2 (each within the scatter of the next); then compound 1.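

In this assay the exchange gives a 1.2-fold lower number from compound 3 to compound 4 (0.07 log units; within the scatter) and so leaves the two compounds indistinguishable, which the earlier step, confined to halogenated benzyl amines, could not show. At this position on a saturated chain carbon bound to an amine nitrogen, neither the chlorine atoms nor an all-aromatic substituent is needed to match compound 3, since 2,3-dihydro-1,4-benzodioxin-2-yl, with its non-aromatic ring and 2 hydrogen-bond acceptors, serves equally well in this pair. No measurement is available to explain this match.

On these data alone, it remains open whether an unsubstituted phenyl, a pyridine ring or a cyclohexyl group would hold the same level here. Also open, as far as these compounds go, is whether 2,3-dihydro-1,4-benzodioxin-2-yl would behave alike on the chains of compound 1 and compound 2.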